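The source may report more compounds than this note shows. Statements on the series, on what has been measured and on what is new or still open speak of the compounds shown alone.

Measured so far:

Compound 1 `O=c1c(Cc2coc3cccc(OCC4CCCCC4)c3c2=O)coc2ccccc12` — in a functional assay on PC-3 cells (Homo sapiens) for antiproliferative activity, read by XTT assay (on this read-out higher numbers stand for weaker inhibition and lower numbers for stronger inhibition), compound 1 gives 4510 nM.
Compound 2 `O=c1c(/C=C/c2coc3ccccc3c2=O)coc2ccccc12` — in this assay compound 2 gives only a limit of the assay, > 10000 nM.
Compound 3 `CC(C)COc1cccc2occ(Cc3coc4ccccc4c3=O)c(=O)c12` — in this assay compound 3 gives 1720 nM.

Compound 3 stands lowest of the two numbers that were obtained; its nearest neighbour is compound 1, and the step of a 2.6-fold lower number from compound 1 to compound 3 (0.42 log units; beyond the scatter) is a modest one. The value of compound 2 is a limit, so it gives no number to compare with.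

Compound 4 `CC(C)CCOc1cccc2occ(Cc3coc4ccccc4c3=O)c(=O)c12` differs from compound 3 in one place: isobutyl in place of isopropyl on a saturated chain carbon bound to an oxygen on an aromatic ring. Among the measured compounds shown here, the only measured step that bears on this position is a 2.6-fold lower number from compound 1 to compound 3 (0.42 log units; beyond the scatter), where a ring was exchanged for a short branched chain. For the measured compounds named here, the present change is smaller, a lengthening of that chain by one carbon, and no measured pair shows what such a lengthening does here. The expected step is therefore a 1.2-fold higher number from compound 3 to compound 4 (0.07 log units; within the scatter), within the scatter. Compound 4 is thus estimated at 2000 nM, with a range from 900 nM to 4500 nM.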

Compound 4, half-maximal inhibitory concentration: > 10000 nM
Compound 4 was reported as a limit (the forecaster's own chance of this, stated with the estimate: 5%); middle value at least 5.0-fold (0.69 log units) from the limit.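

Lengthening the chain by one carbon turns out not to be a minor change at this position: in this assay, isobutyl in place of isopropyl gives an at least 5.8-fold higher number from compound 3 to compound 4 (0.76 log units; beyond the scatter). Compound 1, with its cyclohexyl group, still gives a readable number, and the comparison reads an at least 2.2-fold higher number from compound 1 to compound 4 (0.34 log units; beyond the scatter), so across compound 1, compound 3 and compound 4 the read-out does not simply follow the number of carbons in the group. Both steps are bounds and not exact sizes, since the value of compound 4 is a limit of the assay: the limit of > 10000 nM in this assay, at which 2 of the 4 values shown sit.

The compounds shown leave open whether a shorter chain such as ethyl, or a longer chain such as hexyl, would give a number at this place. They also leave open what an amine or a carboxylic acid would do on the same saturated chain carbon.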